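Urea to cyclopropane amide: weighing a linker swap

A few compounds are considered here, and "the series" means these few. Any claim that something is new, unique, unknown or untested is made for them only; others in the source may bear on it.

Measured so far:
compound 1, `Nc1ccc(CNC(=O)Nc2ccc(CN3C(=O)c4ccccc4C3=O)cc2)cn1`, 4.3 nM in an assay on isolated protein for inhibition of Nicotinamide phosphoribosyltransferase (Homo sapiens), read by mass spectrometry, with stated times of 15 min and 90 min; on this read-out lower numbers stand for stronger inhibition and higher numbers for weaker inhibition
compound 2, `O=C(NCc1cccnc1)Nc1ccc(CN2C(=O)c3ccccc3C2=O)cc1`, 3.1 nM in this assay
compound 3, `O=C(/C=C/c1cccnc1)Nc1ccc(CN2C(=O)c3ccccc3C2=O)cc1`, 10 nM in this assay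

Compound 2 holds the lowest number of the three in this assay; its nearest neighbour is compound 1, with a 1.4-fold lower number from compound 1 to compound 2 (0.14 log units; within the scatter), and its furthest is compound 3, with a 3.2-fold higher number from compound 2 to compound 3 (0.51 log units; beyond the scatter). Only the latter step is beyond the scatter.

Compound 4 is `O=C(Nc1ccc(CN2C(=O)c3ccccc3C2=O)cc1)[C@@H]1C[C@H]1c1cccnc1`. It differs from compound 2 by 2-(pyridin-3-yl)cyclopropyl in place of ((pyridin-3-yl)methyl)amino on a carbonyl carbon. The cyclopropane carries the pyridine on a two-carbon bridge from the carbonyl, much as the ethenyl of compound 3 does, so the step from compound 2 to compound 3 is the one that bears on this change; the step from compound 1 to compound 3 points the same way. Both give a modest rise in number when the urea linker gives way to a carbon-linked amide. Compound 4 is therefore expected to sit near compound 3 rather than compound 2, with the estimated step being a 2.6-fold higher number from compound 2 to compound 4 (0.41 log units; beyond the scatter). The estimate for compound 4 in this assay is 8 nM, within a range from 3 nM to 25 nM.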

Compound 4, half-maximal inhibitory concentration: > 2500 nM
Compound 4 was reported as a limit; the forecaster's own chance of this, stated with the estimate: 2%; middle value at least 310-fold (2.49 log units) from the limit.
By their numbers in this assay, from the lowest: compounds 2 and 1 (each within the scatter of the next); then compound 3. At a limit, above all of these: compound 4.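

In this assay compound 4 is reported only as a limit: the limit of > 2500 nM in this assay, at which 1 of the 4 values shown sits. Against that limit the steps are large on every side: (an at least 800-fold higher number from compound 2 to compound 4 (2.90 log units; beyond the scatter)), (an at least 250-fold higher number from compound 3 to compound 4 (2.39 log units; beyond the scatter)) and (an at least 580-fold higher number from compound 1 to compound 4 (2.76 log units; beyond the scatter)). The earlier compounds shown here showed this carbonyl carbon carrying ((pyridin-3-yl)methyl)amino or 2-(pyridin-3-yl)ethenyl at the cost of only a modest step, whereas compound 4 shows that the position does not accept every group holding a pyridine on a carbon link, and that the change from 2-(pyridin-3-yl)ethenyl to 2-(pyridin-3-yl)cyclopropyl is by itself enough to produce a large step, with no urea involved on either side of it.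

From the compounds shown here alone, compound 4 has 2 defined stereocentres, so it speaks for one stereoisomer only, and whether the mirror-image isomer or the other ring arrangement of the 2-(pyridin-3-yl)cyclopropyl group would reach the same limit stays open. Also open, going by these compounds, is how the saturated open chain, 2-(pyridin-3-yl)ethyl, would behave on this carbonyl carbon, and whether an amino group on the pyridine of compound 4 would change anything.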